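Replacing Hydroxy with Sulfo: Expected Effect on Cytotoxicity

The source may report more compounds than this note shows. Statements on the series, on what has been measured and on what is new or still open speak of the compounds shown alone.

Compound 1 `N#CCCSC(=S)NCc1cccnc1` gives 1030 nM in a functional assay on Bel-7402 cells (Homo sapiens) for cytotoxicity, read by resazurin assay, with a stated time of 72 h; a lower number here means a stronger inhibitor, a higher number a weaker inhibitor.
Compound 2 `N#CCCSC(=S)NCc1cncs1` gives 296000 nM in this assay.
Compound 3 `OCCCSC(=S)NCc1cccnc1` gives 3650 nM in this assay.

Compound 3 stands second highest of the three numbers in this assay: it is separated from compound 1 by a 3.5-fold higher number from compound 1 to compound 3 (0.55 log units; beyond the scatter), while compound 2 lies far higher still. Compound 4 `O=S(=O)(O)CCCSC(=S)NCc1cccnc1` differs from compound 3 by sulfo in place of hydroxy on a saturated chain carbon, three bonds along the chain from a sulfur. Among the measured compounds shown here, no measured step covers this change. The only step shown, cyano to hydroxymethyl on the same chain, was modest, and it concerns a different group at the chain end rather than hydroxy to sulfo itself. For the measured compounds named here, compounds 1 and 2 differ elsewhere in the molecule, and their values show only that the number can move a great deal with changes away from the chain. Going by the values given here, with no direct precedent, compound 4 is expected to sit higher, a step estimated at a 4.1-fold higher number from compound 3 to compound 4 (0.61 log units; beyond the scatter), with wide uncertainty. The estimate for compound 4 in this assay is 15000 nM, expected between 3000 nM and 80000 nM.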

Compound 4, half-maximal inhibitory concentration: 6590 nM
Beside the measured number, compound 4's estimate is 2.3-fold (0.36 log units) above it, and the stated range covers the measured number.
By their numbers in this assay, from the lowest: compound 1; then compounds 3 and 4 (each within the scatter of the next); then compound 2.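

In this assay, putting sulfo in place of hydroxy on a saturated chain carbon, three bonds along the chain from a sulfur, gives a 1.8-fold higher number from compound 3 to compound 4 (0.26 log units; within the scatter), so this read-out does not separate the two groups at this position, even though sulfo brings more heavy atoms. The comparison with the nitrile is clearer: sulfomethyl in place of cyano gives a 6.4-fold higher number from compound 1 to compound 4 (0.81 log units; beyond the scatter), which adds a second chain-end replacement on this core that stands apart from compound 1. Nothing measured here explains these results.

On these data alone, whether an amine or a carboxylic acid at the chain end would fall with compound 3 and compound 4 or nearer compound 1 remains open. Also open, as far as these compounds go, are the effect of a longer chain and whether the hydroxy to sulfo change would read the same on the core of compound 2.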